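The compounds below may be only part of what the source reports. "The series", "measured", "known", "first", "only" and "open" are said of these compounds alone.

Measured in a functional assay on HeLa cells (Homo sapiens) for cytotoxicity, read by MTT assay, with a stated time of 48 h; on this read-out higher numbers stand for weaker inhibition and lower numbers for stronger inhibition:
- Compound 1 `COc1cc(COCc2cn(Cc3cc(C)cnc3Cl)nn2)cc(OC)c1OC`: 264000 nM
- Compound 2 `COc1cc(COCc2cn(Cc3cc(-c4ccc(F)cc4)cnc3Cl)nn2)cc(OC)c1OC`: 49600 nM
- Compound 3 `COc1cc(C2=NOC(COCc3cn(Cc4cc(C)cnc4Cl)nn3)C2)cc(OC)c1OC`: 50500 nM

Compound 2, at 49600 nM, lies within the scatter of compound 3, and both numbers sit well under that of compound 1. Compound 4 `COc1cc(COCc2cn(Cc3cc(-c4ccccc4)cnc3Cl)nn2)cc(OC)c1OC` has hydrogen in place of fluoro on an aromatic carbon, which turns 4-fluorophenyl to phenyl. Among the compounds with values here, the one measured step bearing on this is a 5.3-fold lower number from compound 1 to compound 2 (0.73 log units; beyond the scatter), where 4-fluorophenyl replaced methyl. Within the data shown here, that step exchanged the whole group, and no measured pair tests the fluoro alone. Since compound 4 keeps the aromatic ring gained in that step, the expected change is small, with no direction favoured. The expected step, a 1.1-fold higher number from compound 2 to compound 4 (0.04 log units; within the scatter), is estimated to stay within the scatter. For compound 4 the estimated value is 55000 nM, with an expected range of 25000 nM to 120000 nM.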

Compound 4, half-maximal inhibitory concentration: 41900 nM
Beside the measured number, compound 4's estimate is 1.3-fold (0.12 log units) above it; measured number inside the range.
By their numbers in this assay, from the lowest: compounds 4, 2 and 3 (each within the scatter of the next); then compound 1.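

The fluoro, para to a large group, is now tested on its own: in this assay its exchange for hydrogen leaves the numbers within the scatter (a 1.2-fold lower number from compound 2 to compound 4 (0.07 log units; within the scatter)). The phenyl alone, without the fluoro, also stands beyond the scatter from the methyl compound (a 6.3-fold lower number from compound 1 to compound 4 (0.80 log units; beyond the scatter)), so in these compounds that step does not depend on the fluoro. Nothing available here explains either step. As far as these compounds go, whether a methoxy, an amine or a carboxylic acid in place of the fluoro would change the number remains open. So does whether phenyl in place of methyl would give a similar step on compound 3.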